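Removing One Fluoro: What to Expect for Compound 4

The source may hold more compounds than are shown below. What is called first, only, known or untested is meant among the compounds shown, and "the series" means these compounds.

Of the compounds shown here, three that share one core have been measured in an assay on isolated protein for displacement of a labelled ligand from metabotropic glutamate receptor 5 (Homo sapiens), with a stated time of 60 min, tested at 1 uM; a lower number here means less inhibition, a higher number more inhibition at the concentration tested (going by the name of the read-out). Compound 1 `Cc1ccc(S(=O)(=O)c2cnc3c(F)cccc3c2N2CCC(C)CC2)cc1` gives 93% in this assay. Compound 2 `Cc1ccc(S(=O)(=O)c2cnc3c(F)cccc3c2N2CCC(C)CC2)cc1F` gives 93% in this assay. Compound 3 `CC1CCN(c2c(S(=O)(=O)c3ccc(F)c(F)c3)cnc3ccc(F)cc23)CC1` gives 82% in this assay, the lowest of the three, and its gap to compound 1 and to compound 2 lies beyond the scatter. Compound 1 and compound 2 differ by hydrogen in place of fluoro on an aromatic carbon, and this step gave no change at the digits printed from compound 2 to compound 1 (within the scatter). How the core of compound 3 differs from that of compound 2 is not broken down here.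

Compound 4 `CC1CCN(c2c(S(=O)(=O)c3cccc(F)c3)cnc3ccc(F)cc23)CC1` has not yet been measured. It differs from compound 3 by hydrogen in place of fluoro on an aromatic carbon. This is the same kind of change as that between compound 2 and compound 1, but not the same: there the place was ortho to a methyl group and meta to a large group, here it is ortho to a fluoro group and para to a large group. Because removing a fluoro gave no change at the digits printed from compound 2 to compound 1 (within the scatter), a step of a number 2 percentage points lower from compound 3 to compound 4 (within the scatter) is expected here. Compound 4 is therefore estimated at 80% in this assay, expected to fall between 65% and 92%.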

Compound 4, a percentage reported as inhibition, at one concentration (the size of the read-out at that concentration, not a potency): 76%
Compound 4: the middle estimate sits 4 percentage points above what was measured; the range from low to high includes it.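

Replacing one fluoro with hydrogen, which turns 3,4-difluorophenyl into 3-fluorophenyl, gives a number 6 percentage points lower from compound 3 to compound 4 (within the scatter) in this assay. Set beside the earlier case of the same kind of change, the two cores give steps that cannot be told apart: the same change on two cores in this assay, no change at the digits printed (within the scatter) from compound 2 to compound 1 and a number 6 percentage points lower (within the scatter) from compound 3 to compound 4, 6 percentage points apart, within the scatter of two such steps This shows that, in these two pairs, swapping a fluoro on the aromatic ring for hydrogen did not shift the read-out beyond the usual scatter; it does not show that the step would carry over to every core in the series, as only two pairs are shown, the fluoro sits at a different place in each, and a percentage at one concentration is not a potency.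

The compounds shown leave open what a methoxy group, a nitrile or an amine would do at this place on the aromatic ring. They also leave open whether taking off the remaining fluoro of the 3-fluorophenyl group would stay within the scatter too.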